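The compounds below may be only part of what the source reports. "The series", "measured", "known", "first", "only" and "open" are said of these compounds alone.

Working notes on one series with a shared core, read in a functional assay on A549 cells (Homo sapiens) for inhibition, read by CCK-8 assay, with a stated time of 48 h; on this read-out lower numbers stand for stronger inhibition and higher numbers for weaker inhibition. Compound 1 `COc1cc(-c2ccnc3cc(-c4ccc(Cl)cc4)nn23)cc(OC)c1OC` gives 3070 nM, compound 2 `COc1cc(-c2ccnc3cc(-c4ccc(C)c(C)c4)nn23)cc(OC)c1OC` gives 272 nM, and compound 3 `COc1cc(-c2ccnc3cc(-c4cccc(C)c4)nn23)cc(OC)c1OC` gives 5730 nM. Compound 3 stands on the high side of these numbers, together with compound 1: a 1.9-fold higher number from compound 1 to compound 3 (0.27 log units; within the scatter), which stays within the scatter. Against compound 2 the gap is large: a 21-fold higher number from compound 2 to compound 3 (1.32 log units; beyond the scatter).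

The next structure is compound 4 `COc1ccc(-c2cc3nccc(-c4cc(OC)c(OC)c(OC)c4)n3n2)cc1N`, with 3-amino-4-methoxyphenyl in place of 3-methylphenyl on an aromatic carbon of the five-membered aromatic ring: 3-amino-4-methoxyphenyl in place of 3-methylphenyl on an aromatic carbon.

Within the data shown here, two measured steps bear on this change, and both lead to the 3,4-dimethylphenyl group of compound 2. One is the step already given from compound 2 to compound 3, and the other is an 11-fold lower number from compound 1 to compound 2 (1.05 log units; beyond the scatter). Among the measured compounds shown here, compound 2 is the only measured compound with groups at both of the positions that are numbered in the name of the entering group, so a large step to a lower number is expected, though with wide uncertainty. For the measured compounds named here, no measured compound carries an amino or a methoxy group on this ring, so the size of the step rests on compound 2 at 272 nM alone.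

The estimated step is a 19-fold lower number from compound 3 to compound 4 (1.28 log units; beyond the scatter). For compound 4 the estimated value is 300 nM, with an expected range of 50 nM to 2000 nM.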

Compound 4, half-maximal inhibitory concentration: 138 nM
Beside the measured number, compound 4's estimate is 2.2-fold (0.34 log units) above it; the measured number falls inside the stated range.
By their numbers in this assay, from the lowest: compounds 4 and 2 (each within the scatter of the next); then compounds 1 and 3 (each within the scatter of the next).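

In this assay, the 3-amino-4-methoxyphenyl group brings a large change at this position on the five-membered aromatic ring: a 42-fold lower number from compound 3 to compound 4 (1.62 log units; beyond the scatter), and the step from the 4-chlorophenyl group is of similar size, a 22-fold lower number from compound 1 to compound 4 (1.35 log units; beyond the scatter). Against the 3,4-dimethylphenyl group the change gives a 2.0-fold lower number from compound 2 to compound 4 (0.29 log units; within the scatter), which stays within the scatter, so the low numbers are no longer tied to compound 2 alone and are now shared by two different groups, each substituted at both the 3 and the 4 position, while the singly substituted 4-chlorophenyl and 3-methylphenyl groups of compound 1 and compound 3 remain high. Nothing available explains these steps.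

The compounds shown do not separate the contribution of the amino group from that of the methoxy group, so it remains open whether either one alone, as in 3-aminophenyl or 4-methoxyphenyl, would keep the number low. Going by these compounds, it also remains open whether the amino group itself matters, which a 3,4-dimethoxyphenyl group or an acetamide in its place would test.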